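Replacing the side chain of compound 2

The compounds below may be only part of what the source reports. "The series", "measured", "known", "first", "only" and "open" are said of these compounds alone.

In a functional assay on U-87MG ATCC cells for inhibition, with U-87 MG (Homo sapiens) as the target, read by MTT assay, with a stated time of 72 h (on this read-out lower numbers stand for stronger inhibition and higher numbers for weaker inhibition), compound 1 (`COc1ccccc1-c1csc2cnc(Nc3ccc(NC(=O)[C@H]4CCCNC4)cc3)nc12`) gives 300 nM and compound 2 (`COc1ccccc1-c1csc2cnc(Nc3ccc(NC(=O)CN)cc3)nc12`) gives 210 nM on the same read-out. Among the compounds with values here, compound 2 stands level with compound 1, the only other measured compound, and the one measured step reads as a 1.4-fold lower number from compound 1 to compound 2 (0.15 log units; within the scatter) and so separates them by no real margin.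

The move to compound 3 (`CNC(=O)c1ccc(Nc2ncc3scc(-c4ccccc4OC)c3n2)cc1`) reaches further. It is methylcarbamoyl in place of ((aminomethyl)carbonyl)amino on an aromatic carbon with the change sited on an aromatic carbon of a six-membered aromatic ring of carbon only, para to a large group. The measured step altered only the group on a carbonyl carbon, and both measured compounds keep an amine in that side chain, whereas compound 3 has none. Within the data shown here, that step therefore bears only weakly on this exchange, and no measured pair tests it directly.

In this assay a modest move towards a higher number is expected, only slightly beyond the scatter. The estimated step is a 2.4-fold higher number from compound 2 to compound 3 (0.38 log units; beyond the scatter) on this reckoning. Compound 3 is expected at 500 nM with an estimated range from 150 nM to 1800 nM on this read-out.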

Compound 3, half-maximal inhibitory concentration: 710 nM
Estimate against measurement, compound 3: 1.4-fold (0.15 log units) below, and the stated range covers the measured number.
By their numbers in this assay, from the lowest: compounds 2 and 1 (each within the scatter of the next); then compound 3.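

In this assay, the exchange on this aromatic carbon, para to a large group, now has a measured size: a 3.4-fold higher number from compound 2 to compound 3 (0.53 log units; beyond the scatter), and a 2.4-fold higher number from compound 1 to compound 3 (0.37 log units; beyond the scatter). The earlier step between the two amine-bearing side chains stayed within the scatter, whereas methylcarbamoyl, which has no amine, lies beyond the scatter from both, so this position does respond to a change of the whole group. The compounds shown offer no measurement that accounts for this shift.

The exchange alters several things at once: the amine goes, the side chain shortens, and the group is joined to the aromatic carbon through the carbonyl carbon rather than through nitrogen, so these compounds cannot separate those changes. From the compounds shown here alone, it remains open whether an acetylamino group, which keeps the nitrogen on the aromatic carbon but has no amine in its chain, would read with compound 2 or with compound 3, and whether a carbamoyl group bearing a longer chain that ends in an amine would restore the lower number.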